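The source may report more compounds than this note shows. Statements on the series, on what has been measured and on what is new or still open speak of the compounds shown alone.

Measured compounds:
- compound 1 `Cc1ccc(NC(=S)SCC2=CCOC2=O)cc1`: 91000 nM
- compound 2 `O=C1OCC=C1CSC(=S)Nc1ccccc1`: 16200 nM
- compound 3 `CC(C)N(C(=S)SCC1=CC(=O)OC1)C(C)C`: 49300 nM

Of the compounds shown here, three sharing a core have been tested in a functional assay on EC9706 cells (Homo sapiens) for antiproliferative activity, read by MTT assay, with a stated time of 72 h; a lower number here means a stronger inhibitor, a higher number a weaker inhibitor. Among the compounds with values here, compound 2 gives the lowest number of the three, and both gaps are beyond the scatter: no single-place step connects compound 2 and compound 3, but the value of compound 3, 49300 nM, sits clearly higher, and compound 1 is higher still. Compound 2 can therefore be called the strongest inhibitor of the three.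

Compound 4 `O=C1OCC=C1CSC(=S)Nc1ccc(Cl)cc1` has not been measured. It differs from compound 2 by chloro in place of hydrogen on an aromatic carbon, the new group sitting on an aromatic carbon of a six-membered aromatic ring of carbon only, para to a large group.

Within the data shown here, only one measured step bears on this change: a 5.6-fold lower number from compound 1 to compound 2 (0.75 log units; beyond the scatter), a methyl leaving an aromatic carbon. Read in the opposite direction, placing a substituent on that ring raised the number modestly. Chloro is not methyl, so the step is only a rough guide, but a modest rise in this assay is the most defensible expectation.

On that basis compound 4 is expected to give 35000 nM, within a range of 10000 nM to 100000 nM, meaning an expected step of a 2.2-fold higher number from compound 2 to compound 4 (0.33 log units; beyond the scatter).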

Compound 4, half-maximal inhibitory concentration: "not active" (no number reported)
The entry for compound 4 holds no number; there is nothing to compare the estimate with.
By their numbers in this assay, from the lowest: compound 2; then compounds 3 and 1 (each within the scatter of the next).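

In this assay, within the data shown here, compound 4 is recorded as not active, without a number, so no step from compound 2 to compound 4 can be read. The compounds shown leave open how far chloro in place of hydrogen on this ring moves the number, if a number can be obtained at all. No measurement shown offers an explanation for this result.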